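Dropping a Chloro Atom from an Inactive Hydrazone

The source may report more compounds than this note shows. Statements on the series, on what has been measured and on what is new or still open speak of the compounds shown alone.

Compound 1 `COc1ccc(OC)c(/C=C/c2nnc(Nc3ccc(Cl)cc3)o2)c1` — in a functional assay on MCF7 cells (Homo sapiens) for antiproliferative activity, read by sulforhodamine B assay, with a stated time of 48 h (a lower number here means that less compound is tolerated, a higher number that more compound is tolerated), compound 1 gives only an assay limit, > 100000 nM.
Compound 2 `COc1ccc(OC)c(/C=C/C(=O)N/N=C/c2ccc(Cl)cc2)c1` — in this assay compound 2 also gives only an assay limit, > 100000 nM.

Compound 2 therefore stands at the limit of > 100000 nM in this assay, at which 2 of the 2 values shown sit, and no actual number is known for it. Compound 3 `COc1ccc(OC)c(/C=C/C(=O)N/N=C/c2ccccc2)c1` differs from compound 2 by hydrogen in place of chloro on an aromatic carbon. Among the compounds with values here, no measured step between two compounds exists here, so in this assay no change beyond the usual scatter is expected from this small change. Compound 3 is expected to give roughly 150000 nM, within 50000 nM to 500000 nM, most likely again reported as a limit. The step this estimate implies, a step that the limit leaves unreadable from compound 2 to compound 3, is expected to be negligible.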

Compound 3, concentration lethal to 50% of the cells: > 100000 nM
Compound 3: a limit, no number; the forecaster's own chance of this, stated with the estimate: 75%; the middle value lies beyond the limit too.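

Compound 2 and compound 3 each give only a limit in this assay, so no step between them can be read: the limit of > 100000 nM in this assay, at which 3 of the 3 values shown sit.

The compounds shown leave open whether going from 4-chlorophenyl to phenyl changes the lethal concentration at all.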